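A few compounds are considered here, and "the series" means these few. Any claim that something is new, unique, unknown or untested is made for them only; others in the source may bear on it.

Three compounds from one series share the same core and differ only at the edges. Compound 1 `COc1cc2c(Oc3ccc(NC(=O)c4nnn(-c5ccccc5C)c4C)cc3F)ccnc2cc1OCCCN1CCCC1` has a methyl-substituted phenyl and a pyrrolidine at its chain end; in a functional assay on A549 cells (Homo sapiens) for cytotoxicity, read by MTT assay, with a stated time of 72 h (on this read-out lower numbers stand for stronger inhibition and higher numbers for weaker inhibition), compound 1 gives 380 nM. Compound 2 `COc1cc2c(Oc3ccc(NC(=O)c4nnn(-c5ccc(F)cc5)c4C(F)(F)F)cc3F)ccnc2cc1OCCCN1CCCCC1` carries a trifluoromethyl, a fluorophenyl and a piperidine; in this assay compound 2 gives 110 nM. Compound 3 `COc1cc2c(Oc3ccc(NC(=O)c4nnn(-c5ccc(F)c(F)c5)c4C(F)(F)F)cc3F)ccnc2cc1OCCCN1CCCCC1` adds a second fluorine to that phenyl and in this assay gives 160 nM. Among the three numbers compound 3 stands second highest; the step from compound 2 to compound 3 is a 1.5-fold higher number from compound 2 to compound 3 (0.16 log units; within the scatter), so the two sit within the scatter of each other, while compound 1 lies further away.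

Compound 4 `COc1cc2c(Oc3ccc(NC(=O)c4nnn(-c5ccc(F)c(F)c5)c4C(F)(F)F)cc3F)ccnc2cc1OCCCN1CCC(C)CC1` is built from compound 3 by a single change: methyl in place of hydrogen on a saturated ring carbon of the piperidine, read one bond further out as piperidin-1-yl to 4-methylpiperidin-1-yl. For the measured compounds named here, none of the measured steps touches this ring; the only measured step, from compound 2 to compound 3, concerns the fluorinated phenyl and was within the scatter. Going by the values given here, with no comparable step to lean on, the expectation for compound 4 is a step of no change at the digits printed from compound 3 to compound 4 (within the scatter), nothing beyond the scatter. Compound 4 is therefore estimated at 160 nM, with a range from 70 nM to 370 nM.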

Compound 4, half-maximal inhibitory concentration: 140 nM
Compound 4: the middle estimate sits 1.1-fold (0.06 log units) above what was measured, within the range that was stated.
By their numbers in this assay, from the lowest: compounds 2, 4 and 3 (each within the scatter of the next); then compound 1.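

For the compounds shown here, this is the first measured step at the saturated ring at the end of the chain, since the earlier step concerned only the fluorinated phenyl. Going from piperidin-1-yl to 4-methylpiperidin-1-yl, in this assay the change gives a 1.1-fold lower number from compound 3 to compound 4 (0.06 log units; within the scatter) and so leaves compound 3 and compound 4 indistinguishable on this read-out. For this pair, then, the ring carbon three ring bonds from the ring nitrogen can carry a methyl without the number moving beyond the scatter, although no supporting measurement says how this methyl acts in the cells.

On these data alone, a single small group at one ring carbon says little about larger or different groups, so it remains open whether an ethyl, a hydroxyl, a dimethylamino group or a phenyl at the same place would also stay within the scatter. As far as these compounds go, compound 1 differs from the others in more than one place, so the contribution of its pyrrolidine cannot be separated from that of its other groups, and it also remains open how a morpholine at the chain end would compare.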